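Ester Alkyl Shortening in a Bromophenyl Terpenoid Series

The source may hold more compounds than are shown below. What is called first, only, known or untested is meant among the compounds shown, and "the series" means these compounds.

Measured compounds:
Compound 1, `C=C(C)[C@H]1CC=C(C)[C@@]2(O)[C@@H]1[C@H](c1ccccc1Br)O[C@@H]2C(=O)OCC1CC1`, gives 50000 nM in a functional assay on KB3 cells (Homo sapiens) for antiproliferative activity, read by MTT assay, with a stated time of 96 h; a higher number here means a weaker inhibitor, a lower number a stronger inhibitor.
Compound 2, `C=C(C)[C@H]1CC=C(C)C2=CO[C@@H](c3ccccc3Br)[C@@H]21`, gives 4000 nM in this assay.

Of the two measured compounds, compound 1 stands with the highest number; its nearest neighbour, compound 2, shows a lower number in this assay, a gap that lies beyond the usual scatter, although compound 2 carries neither the hydroxyl nor the ester of compound 1 and the two are not joined by a single-point change.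

Compound 3, `C=C(C)[C@H]1CC=C(C)[C@@]2(O)[C@@H]1[C@H](c1ccccc1Br)O[C@@H]2C(=O)OCC`, has not yet been measured. It differs from compound 1 in one place: methyl in place of cyclopropyl on a saturated chain carbon bound to an oxygen next to a carbonyl group. The shared core of compound 1, its bromophenyl substituent, its tertiary hydroxyl and the ester linkage are all kept; only the alkyl part of the ester is shortened.

For the measured compounds named here, no measured pair shows what such an ester alkyl change does in this assay. With nothing in the data pointing either way, the step from compound 1 to compound 3 is expected to stay within the scatter, as an estimated no change at the digits printed from compound 1 to compound 3 (within the scatter). Compound 3 is therefore expected to give about 50000 nM, within a range of 15000 nM to 150000 nM.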

Compound 3, half-maximal inhibitory concentration: 20000 nM
Compound 3: the middle estimate sits 2.5-fold (0.40 log units) above what was measured; measured number inside the range.
By their numbers in this assay, from the lowest: compound 2; then compound 3; then compound 1.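

In this assay, methyl in place of cyclopropyl on a saturated chain carbon bound to an oxygen next to a carbonyl group gives a 2.5-fold lower number from compound 1 to compound 3 (0.40 log units; beyond the scatter), a modest step. For the compounds shown here, this is the first single-point change, and it shows that the alkyl part of the ester is not silent in this assay, even with the shared core, the bromophenyl substituent, the tertiary hydroxyl and the ester linkage all kept, and that the cyclopropylmethoxycarbonyl to ethoxycarbonyl change moves the number in the stronger direction. No measurement bears on what lies behind this step.

A single pair gives a direction for this one change only, and it leaves open how a longer chain such as butyl, a chain carrying an amine, or a free carboxylic acid in place of the ester would read in this assay. It also leaves open whether the same cyclopropylmethoxycarbonyl to ethoxycarbonyl change would give a step of similar size on another compound of the series.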